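Swapping nitro for ethoxy on a weak antiproliferative thiocarbamate

This account rests on a few compounds, and the source may have more. Where it says the series, first, only, none or still open, it means among the compounds named here.

Within the data shown here, compound 3 `O=C1OCC[C@@H]1NC(=S)SCCOc1ccccc1[N+](=O)[O-]` gives 33400 nM in a functional assay on DU-145 cells (Homo sapiens) for antiproliferative activity, read by MTT assay, with a stated time of 72 h (a higher number here means a weaker inhibitor, a lower number a stronger inhibitor), the lowest of the two numbers known. Compound 1 `O=C1OCC[C@@H]1NC(=S)SCCOc1ccccc1` gives 63800 nM. Compound 2 `O=C1OCC[C@@H]1NC(=S)SCCOc1ccccc1Cc1ccccc1` reaches only the assay limit, > 64000 nM (the limit of > 64000 nM in this assay, at which 1 of the 3 values shown sits). The change to compound 4 `CCOc1ccccc1OCCSC(=S)N[C@H]1CCOC1=O` is ethoxy in place of nitro on an aromatic carbon. Among the measured compounds shown here, two measured steps bear on it: a 1.9-fold lower number from compound 1 to compound 3 (0.28 log units; within the scatter), and an at least 1.9-fold lower number from compound 2 to compound 3 (0.28 log units; that floor lies within the scatter). For the measured compounds named here, removing the nitro undoes the first of these, so a small rise is expected in this assay; the incoming ethoxy has no measured precedent, though the benzyl of compound 2 gave a number no lower from compound 1 to compound 2 (the limit leaves the size open). Compound 4 is therefore estimated at 60000 nM, between 30000 nM and 120000 nM, which would mean a 1.8-fold higher number from compound 3 to compound 4 (0.25 log units; within the scatter).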

Compound 4, half-maximal inhibitory concentration: 28300 nM
The estimate for compound 4 lay 2.1-fold (0.33 log units) above the measured number, and the stated range ends above it.
By their numbers in this assay, from the lowest: compounds 4, 3 and 1 (each within the scatter of the next, the first and the last beyond it). At a limit, above all of these: compound 2.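

In this assay, ethoxy and nitro cannot be told apart on this aromatic carbon, with a 1.2-fold lower number from compound 3 to compound 4 (0.07 log units; within the scatter) as the step between them. Set against hydrogen at the same place, ethoxy gives a 2.3-fold lower number from compound 1 to compound 4 (0.35 log units; beyond the scatter) as the first step from hydrogen here to clear the scatter with a readable size. Compound 2 stands at a limit, so an at least 2.2-fold lower number from compound 2 to compound 4 (0.35 log units; beyond the scatter) is only a floor: the limit of > 64000 nM in this assay, at which 1 of the 4 values shown sits.

Going by these compounds, whether an amine, a carboxylic acid or a longer chain such as butoxy would be tolerated at this place stays open. So does whether any group here can move these weak numbers much further down.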